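Lengthening an Ether Chain in a Chemokine Receptor Antagonist Series

A few compounds are considered here, and "the series" means these few. Any claim that something is new, unique, unknown or untested is made for them only; others in the source may bear on it.

Three compounds built on one shared core were tested in a functional assay on U2OS cells for antagonist activity at C-X-C chemokine receptor type 3 (Homo sapiens), read by beta-arrestin recruitment; a higher number here means a weaker inhibitor, a lower number a stronger inhibitor. Compound 1 `CCOc1ncc(-c2nc(C(F)(F)F)sc2N2CCN(C(=O)Cn3nc(C)nc3C)[C@H](C)C2)cn1` gives 173 nM, compound 2 `Cc1nc(C)n(CC(=O)N2CCN(c3sc(C(F)(F)F)nc3-c3cnc(OC(C)C)nc3)C[C@H]2C)n1` gives 138 nM, and compound 3 `COc1ccc(-c2nc(C(F)(F)F)sc2N2CCN(C(=O)Cn3nc(C)nc3C)[C@H](C)C2)cn1` gives 1170 nM. Compound 3 differs from compound 1 by 6-methoxypyridin-3-yl in place of 2-ethoxypyrimidin-5-yl on an aromatic carbon, a change that gave a 6.8-fold higher number from compound 1 to compound 3 (0.83 log units; beyond the scatter); the step of an 8.5-fold higher number from compound 2 to compound 3 (0.93 log units; beyond the scatter) points the same way. Compound 2 differs from compound 1 by methyl in place of hydrogen on a saturated chain carbon bound to an oxygen on an aromatic ring and a saturated chain carbon, which gave a 1.3-fold lower number from compound 1 to compound 2 (0.10 log units; within the scatter).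

Compound 4 `CCOc1ccc(-c2nc(C(F)(F)F)sc2N2CCN(C(=O)Cn3nc(C)nc3C)[C@H](C)C2)cn1` has not been measured. It differs from compound 3 by methyl in place of hydrogen on a saturated chain carbon bound to an oxygen on an aromatic ring. This is the same kind of change as the one from compound 1 to compound 2, but not the same: there the carbon that gains the methyl is bound to an oxygen on an aromatic ring and a saturated chain carbon, here only to an oxygen on an aromatic ring, and the two cores differ as described above. The step of a 1.3-fold lower number from compound 1 to compound 2 (0.10 log units; within the scatter) stayed within the scatter, so only a small move is expected for compound 4, roughly a 1.3-fold lower number from compound 3 to compound 4 (0.11 log units; within the scatter). Compound 4 is therefore estimated at 900 nM, with a likely range from 400 nM to 2000 nM.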

Compound 4, half-maximal inhibitory concentration: 505 nM
The estimate for compound 4 lay 1.8-fold (0.25 log units) above the measured number, and the stated range covers the measured number.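

In this assay, extending methoxy to ethoxy on the 6-methoxypyridin-3-yl group gave a 2.3-fold lower number from compound 3 to compound 4 (0.36 log units; beyond the scatter), a modest strengthening of the inhibitor when this step is read alone. Set beside the same change on the core of compound 1, the step shows no measurable difference in size between the two cores: the same change on two cores in this assay, a 1.3-fold lower number (0.10 log units; within the scatter) from compound 1 to compound 2 and a 2.3-fold lower number (0.36 log units; beyond the scatter) from compound 3 to compound 4, 1.8-fold (0.27 log units) apart, within the scatter of two such steps. Among the compounds shown here, this rests on only two pairs and does not establish a fixed size for the change on other cores, and the ethoxy group does not make up for the change of aromatic group, as a 2.9-fold higher number from compound 1 to compound 4 (0.47 log units; beyond the scatter) and a 3.7-fold higher number from compound 2 to compound 4 (0.56 log units; beyond the scatter) show.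

The compounds shown leave open whether a 6-isopropoxypyridin-3-yl group would continue the trend from methoxy to ethoxy on this core. They also leave open how a longer chain such as butoxy, or an amine in place of the ether oxygen, would read in this assay.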